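The source may hold more compounds than are shown below. What is called first, only, known or untested is meant among the compounds shown, and "the series" means these compounds.

The measured compounds:
Compound 1, `Nc1ccc(Oc2ccccc2-c2ccc(S(=O)(=O)NCCNC(=O)Nc3ccc(Cl)cc3)s2)cc1`: in a functional assay on HeLa cells (Homo sapiens) for inhibition, read by CCK-8 assay, with a stated time of 48 h (on this read-out higher numbers stand for weaker inhibition and lower numbers for stronger inhibition), compound 1 gives > 20000 nM, which is a limit of the assay and not a number.
Compound 2, `COc1ccc(Oc2ccc([N+](=O)[O-])cc2-c2ccsc2S(=O)(=O)N2CCN(C(=O)Nc3ccc([N+](=O)[O-])cc3)CC2)cc1OC`: in this assay compound 2 gives > 50000 nM, again a limit rather than a number.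
Compound 3, `Cc1ccc(-c2ccsc2S(=O)(=O)NCCNC(=S)Nc2cc(C(F)(F)F)cc(C(F)(F)F)c2)c(Oc2ccc(O)c(O)c2)c1`: in this assay compound 3 gives 8000 nM.

Among the compounds with values here, compound 3 thus holds the only true number among the three, the other two being limits. Compound 4, `O=S(=O)(NCCNC(=S)Nc1cc(C(F)(F)F)cc(C(F)(F)F)c1)c1sccc1-c1ccccc1Oc1ccc(O)c(O)c1`, differs from compound 3 by a single change: hydrogen in place of methyl on an aromatic carbon. No measured step of this kind exists among these compounds. The change is small, so the expected step in this assay is a 1.3-fold higher number from compound 3 to compound 4 (0.10 log units; within the scatter), within the usual scatter and in no particular direction. Compound 4 is therefore estimated at 10000 nM, with a range from 4000 nM to 30000 nM.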

Compound 4, half-maximal inhibitory concentration: > 50000 nM
Compound 4: only a limit was reported; the forecaster's own chance of this, stated with the estimate: 25%; middle value at least 5.0-fold (0.69 log units) from the limit.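

Swapping methyl for hydrogen at this position, para to a large group, is a small edit with a large result: in this assay it gives an at least 6.2-fold higher number from compound 3 to compound 4 (0.79 log units; beyond the scatter) for the loss of one carbon. From the compounds shown here alone, compound 4 gives > 50000 nM here, a limit of the assay and not a number, so the step's full size stays unknown. Within the data shown here, this is the first comparison in the set that changes only one place, and it shows that this methyl group cannot be treated as a minor detail.

Going by these compounds, whether a larger ethyl group here would retain, improve or lose the inhibition seen with compound 3 remains open. The compounds shown also cannot tell why removing the methyl has this effect.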